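Adding a Methoxy Group and Tolerance in Cells

A few compounds are considered here, and "the series" means these few. Any claim that something is new, unique, unknown or untested is made for them only; others in the source may bear on it.

Four compounds built on one shared core are considered here. Compound 1 `COc1ccc(-c2nc3cc(/C(C)=N/O)ccc3[nH]2)c(OC)c1` and compound 2 `COc1ccc(-c2nc3cc(/C(C)=N/O)ccc3[nH]2)c(OC)c1OC` differ in a single place: methoxy in place of hydrogen on an aromatic carbon. Compound 3 `COc1ccc(-c2nc3cc(/C(C)=N/NC(N)=O)ccc3n2C2CCCCC2)cc1` differs from compound 1 in more than one place, and the difference between the two cores is not broken down here. Compound 4 `COc1ccc(-c2nc3cc(/C(C)=N/NC(N)=O)ccc3n2C2CCCCC2)c(OC)c1` stands to compound 3 as compound 2 stands to compound 1: methoxy in place of hydrogen on an aromatic carbon. The surroundings are not identical, since in the first pair the new group sits ortho to two methoxy groups and meta to a large group, whereas in the second pair it sits ortho to a large group and meta to a methoxy group, so this is the same kind of change rather than the same change.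

In an ADME assay on MT4 cells (Homo sapiens) for cytotoxicity, read by MTT assay, with a stated time of 96 h (a higher number here means that more compound is tolerated, a lower number that less compound is tolerated), compound 1 gives >= 100000 nM, and that figure is a limit of the assay rather than a measured number. In this assay compound 2 gives 51000 nM. The step between them is an at least 1.9-fold lower number from compound 1 to compound 2 (0.29 log units; that floor lies within the scatter). Among the measured compounds shown here, only one of the three values shown reaches that limit: the limit of >= 100000 nM in this assay, at which 1 of the 3 values shown sits. In this assay compound 3 gives "not determined" (no result reported), so there is no starting point from which a step to compound 4 could be counted.

Taken together, the one measured pair gives only a floor that lies within the scatter, so the expectation for compound 4 rests on that pair alone and must stay loose. Compound 4 is expected to sit near 60000 nM in this assay. The estimated range for compound 4 runs from 20000 nM to 150000 nM.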

Compound 4, half-maximal cytotoxic concentration: 23000 nM
Estimate against measurement, compound 4: 2.6-fold (0.42 log units) above; measured number inside the range.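

In this assay, among the compounds shown here, compound 3 gives "not determined" (no result reported) and compound 4 gives 23000 nM as its result, so no step from compound 3 to compound 4 can be read. Nothing shown here bears on the number for compound 4. From the compounds shown here alone, what stays open is whether methoxy in place of hydrogen on an aromatic carbon shifts the number in this assay at all in this second setting.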